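Lengthening the amide chain of compound 3

A few compounds are considered here, and "the series" means these few. Any claim that something is new, unique, unknown or untested is made for them only; others in the source may bear on it.

In a physicochemical assay for lipophilicity (on this read-out lower numbers stand for lower lipophilicity and higher numbers for higher lipophilicity), compound 1 (`CCCOC(=O)c1ccc(S(N)(=O)=O)cc1`) gives 1.75 and compound 2 (`CCCCOC(=O)c1ccc(S(N)(=O)=O)cc1`) gives 2.34. Compound 3 (`CNC(=O)c1ccc(S(N)(=O)=O)cc1`) gives the lowest of the three numbers (-0.31). Compound 4 (`CCCCCCNC(=O)c1ccc(S(N)(=O)=O)cc1`) differs from it by pentyl in place of hydrogen on a saturated chain carbon bound to an amide-type nitrogen. Among the measured compounds shown here, the nearest precedent is a modest step from adding methyl to a chain (a number 0.59 log units higher from compound 1 to compound 2 (beyond the scatter)). The large steps (a number 2.06 log units lower from compound 1 to compound 3 (beyond the scatter) and a number 2.65 log units lower from compound 2 to compound 3 (beyond the scatter)) replace the group on the carbonyl carbon and bear only indirectly. Pentyl is a larger addition than that methyl, so a large upward step in this assay is expected (a number 2.71 log units higher from compound 3 to compound 4 (beyond the scatter)). The estimate for compound 4 is 2.4 (expected range 1.8 to 3).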

Compound 4, partition coefficient: 2.05
Compound 4: middle estimate off by 0.35 log units, on the high side; the range from low to high includes it.
By their numbers in this assay, from the lowest: compound 3; then compounds 1, 4 and 2 (each within the scatter of the next, the first and the last beyond it).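

In this assay, the amide nitrogen position tolerates a large change: extending methyl to hexyl gives a number 2.36 log units higher from compound 3 to compound 4 (beyond the scatter). Among the compounds shown here, the earlier chain step, a number 0.59 log units higher from compound 1 to compound 2 (beyond the scatter), was on an ester chain, so this is the first chain extension read on the amide. No measurement on hand accounts for the size of this step.

Going by these compounds, how the number runs through propyl or butyl on the amide remains open, as does whether octyl would extend the rise. On these data alone, the effect of a hexyl chain ending in an amine or a carboxylic acid is also open.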